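Triazole series: every value sits at the assay limit

The source may report more compounds than this note shows. Statements on the series, on what has been measured and on what is new or still open speak of the compounds shown alone.

Compound 1 `C=C1C[C@]23C[C@@]1(O)CC[C@H]2c1ccc(OS(=O)(=O)c2ccc(C)cc2)c(C)c1[C@@H]3Cn1cc(-c2ccc(Cl)cc2)nn1` and compound 2 `C=C1C[C@]23C[C@@]1(O)CC[C@H]2c1ccc(OS(=O)(=O)c2ccc(C)cc2)c(C)c1[C@@H]3Cn1cc(-c2ccc(OC)cc2)nn1` share one core and differ in a single place, (chloro in place of methoxy on an aromatic carbon). Compound 3 `C=C1C[C@]23C[C@@]1(O)CC[C@@H]2c1cccc(C)c1[C@@H]3Cn1cc(-c2ccc(OC)cc2)nn1` carries the same methoxyphenyl triazole as compound 2 on a different core; the difference between the two cores is not broken down here. Compound 4 `C=C1C[C@]23C[C@@]1(O)CC[C@@H]2c1cccc(C)c1[C@@H]3Cn1cc(-c2ccc(Cl)cc2)nn1` stands to compound 3 as compound 1 stands to compound 2, (chloro in place of methoxy on an aromatic carbon), and the place of the change is the same in both pairs.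

In a functional assay on A549 cells (Homo sapiens) for cytotoxicity, read by MTT assay, with a stated time of 4 days (a higher number here means a weaker inhibitor, a lower number a stronger inhibitor), compound 1 gives > 20000 nM, which is a limit of the assay and not a number. Compound 2 gives > 20000 nM in this assay, also a limit. Compound 3 gives > 20000 nM in this assay, again a limit. The step that the two limits leave unreadable from compound 2 to compound 1 cannot be read, because of the limit of > 20000 nM in this assay, at which 3 of the 3 values shown sit.

Within the data shown here, for compound 4 the same change is applied to compound 3, whose value in this assay is a limit, and the only measured instance of the change, a step that the two limits leave unreadable from compound 2 to compound 1, gave no readable size. The step that the limit leaves unreadable from compound 3 to compound 4 is therefore expected to be small or unreadable. Compound 4 is expected at 30000 nM in this assay, with a plausible range from 15000 nM to 100000 nM, and most likely it will again be reported only as a limit.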

Compound 4, half-maximal inhibitory concentration: > 20000 nM
Compound 4: only a limit was reported; the forecaster's own chance of this, stated with the estimate: 90%; the middle value does not contradict the limit.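

No new step can be read: compound 4 adds only a limit, and the pair of compound 3 and compound 4 stays as unreadable as that of compound 2 and compound 1, because both pairs rest on the same value: the limit of > 20000 nM in this assay, at which 4 of the 4 values shown sit.

The compounds shown leave open whether the change from 4-methoxyphenyl to 4-chlorophenyl, or the difference between the two cores, has any effect in this assay.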